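A few compounds are considered here, and "the series" means these few. Any claim that something is new, unique, unknown or untested is made for them only; others in the source may bear on it.

In a functional assay on the whole organism with Rattus norvegicus as the target, in the maximal electroshock model (a higher number here means that more compound is needed for the effect, a lower number that less compound is needed), compound 1 `CCNc1ncnc2c1ncn2Cc1ccccc1F` gives 4.9 mg/kg, compound 2 `CCCNc1ncnc2c1ncn2Cc1ccccc1F` gives 5.1 mg/kg, and compound 3 `Fc1ccccc1Cn1cnc2c(NCC3CC3)ncnc21` gives 4.3 mg/kg. Compound 3 holds the lowest of the three numbers, yet a 1.1-fold lower number from compound 1 to compound 3 (0.06 log units; within the scatter) and a 1.2-fold lower number from compound 2 to compound 3 (0.07 log units; within the scatter) are within the scatter, as is a 1.0-fold higher number from compound 1 to compound 2 (0.02 log units; within the scatter). Compound 4 `CN(c1ncnc2c1ncn2Cc1ccccc1F)C1CC1` differs from compound 3 by cyclopropyl(methyl)amino in place of (cyclopropylmethyl)amino on an aromatic carbon. The three measured steps all change the chain on the nitrogen while keeping its hydrogen; none removes the hydrogen-bond donor, so they bear on compound 4 only in showing that variation at this position has stayed within the scatter. On these data alone, the loss of the donor is untested, so the step is expected to be a 1.6-fold higher number from compound 3 to compound 4 (0.21 log units; within the scatter) with wide uncertainty. Compound 4 is estimated at 7 mg/kg in this assay, between 3 mg/kg and 20 mg/kg.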

Compound 4, dose for half-maximal effect: 6.8 mg/kg
Compound 4: middle estimate off by 1.0-fold (0.01 log units), on the high side; the range from low to high includes it.
By their numbers in this assay, from the lowest: compounds 3, 1, 2 and 4 (each within the scatter of the next).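

With the hydrogen-bond donor on the nitrogen gone, this assay gives a 1.6-fold higher number from compound 3 to compound 4 (0.20 log units; within the scatter) and a 1.3-fold higher number from compound 2 to compound 4 (0.12 log units; within the scatter) and a 1.4-fold higher number from compound 1 to compound 4 (0.14 log units; within the scatter) as the steps. All three stay within the scatter, so at this aromatic carbon the tertiary cyclopropyl(methyl)amino is not separated from the three secondary amines, and the donor is shown not to be needed for activity in this model. No evidence bears on this result.
Still open, on these data alone, is whether a morpholine or a longer chain at this aromatic carbon would give a step beyond the scatter.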